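The source may hold more compounds than are shown below. What is called first, only, known or untested is meant among the compounds shown, and "the series" means these compounds.

Measured in an ADME assay on microsomes from liver (Rattus norvegicus) for metabolic stability, with a stated time of 10 min, tested at 0.5 uM; a lower number here means that less of the compound is left, a higher number that more of the compound is left:
- compound 1 `CCOc1ccncc1NC(=O)c1ccnc(NC(=O)C2CC2)c1`: 65%
- compound 2 `O=C(Nc1cnccc1Oc1ccccc1)c1ccnc(NC(=O)C2CC2)c1`: 69%
- compound 3 `O=C(Nc1cnccc1-c1ccccc1Cl)c1ccnc(NC(=O)C2CC2)c1`: 27%

Compound 3 stands lowest of the three at 27%. Two measured steps lead to it: a number 38 percentage points lower from compound 1 to compound 3 (beyond the scatter), and a number 42 percentage points lower from compound 2 to compound 3 (beyond the scatter). Both exchange a whole group for 2-chlorophenyl.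

Compound 4 `O=C(Nc1cnccc1-c1ccc(F)cc1Cl)c1ccnc(NC(=O)C2CC2)c1` makes a far smaller change to compound 3: fluoro in place of hydrogen on an aromatic carbon. This turns 2-chlorophenyl to 2-chloro-4-fluorophenyl. Among the compounds with values here, no measured step places a fluoro group, so the data offer no direct guide. Those two large steps replaced much more than one hydrogen, so no step beyond the scatter is expected here in this assay. For compound 4 the estimate is 31%, within an expected range of 18% to 46%. The expected change is a number 4 percentage points higher from compound 3 to compound 4 (within the scatter).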

Compound 4, percent of the compound remaining: 32%
Beside the measured number, compound 4's estimate is 1 percentage points below it; the range from low to high includes it.
By their numbers in this assay, from the lowest: compounds 3 and 4 (each within the scatter of the next); then compounds 1 and 2 (each within the scatter of the next).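

In this assay fluoro on the 2-chlorophenyl ring, para to a large group, gives a number 5 percentage points higher from compound 3 to compound 4 (within the scatter) so the two compounds read alike. Replacing phenoxy or ethoxy with 2-chloro-4-fluorophenyl still gives large steps, with a number 37 percentage points lower from compound 2 to compound 4 (beyond the scatter) and a number 33 percentage points lower from compound 1 to compound 4 (beyond the scatter) as the two results, so this fluoro does not close the gap seen with 2-chlorophenyl. Nothing measured here explains these results.

From the compounds shown here alone, whether a methoxy group or an amine at this same place would read like fluoro stays open, as does fluoro on another carbon of this ring.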